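The source may hold more compounds than are shown below. What is called first, only, known or untested is meant among the compounds shown, and "the series" means these compounds.

Three compounds were tested in a functional assay on HeLa cells (Homo sapiens) for cytotoxicity, read by MTT assay, with a stated time of 48 h; a higher number here means a weaker inhibitor, a lower number a stronger inhibitor. Compound 1 `O=C1C(O)=C(C(c2ccccc2)c2c(-c3ccccc3)[nH]c3ccccc23)C(=O)c2ccccc21` gives 18800 nM, the highest of the three numbers. Compound 2 `O=C1C(O)=C(C(c2ccc([N+](=O)[O-])cc2)c2c[nH]c3ccccc23)C(=O)c2ccccc21` gives 14800 nM, which lies within the usual scatter of the number for compound 1. Compound 3 `Cc1[nH]c2ccccc2c1C(C1=C(O)C(=O)c2ccccc2C1=O)c1ccc([N+](=O)[O-])cc1` gives 4570 nM, and the only single-point step among these measured compounds is a 3.2-fold lower number from compound 2 to compound 3 (0.51 log units; beyond the scatter).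

Compound 4 `O=C1C(O)=C(C(c2cccc([N+](=O)[O-])c2)c2c(-c3ccccc3)[nH]c3ccccc23)C(=O)c2ccccc21` differs from compound 1 in one place: nitro in place of hydrogen on an aromatic carbon. For the measured compounds named here, no measured step shows this change. The step from compound 2 to compound 3 concerns a methyl on the shared core, not a nitro on the phenyl, so it offers no direct guide. Compounds 1 and 2 differ in two places at once, one of them a nitro on the phenyl, and their numbers sit within the scatter of each other, which suggests no large effect. The expectation for compound 4 is therefore a step of a 1.3-fold lower number from compound 1 to compound 4 (0.10 log units; within the scatter), within the scatter. The estimate for compound 4 in this assay is 15000 nM, with a range from 6000 nM to 40000 nM.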

Compound 4, half-maximal inhibitory concentration: 12500 nM
For compound 4 the middle estimate is 1.2-fold (0.08 log units) above the measured one, within the range that was stated.
By their numbers in this assay, from the lowest: compound 3; then compounds 4, 2 and 1 (each within the scatter of the next).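

In this assay, the change from phenyl to 3-nitrophenyl on the core of compound 1 gives a 1.5-fold lower number from compound 1 to compound 4 (0.18 log units; within the scatter). For the compounds shown here, this is the first reading of a nitro group on its own, since no earlier step isolated this change, and it shows that adding these 3 heavy atoms at this aromatic carbon does not move the number beyond the scatter on this core. No measurement shown here offers an explanation for this result.

Going by these compounds, it remains open whether an amine or a carboxylic acid at this same carbon would also leave the number within the scatter. Also unknown is whether a nitro group on another carbon of this ring, or on a core with a different substituent, would give a similar result.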